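Two Inverted Stereocentres, Potency Expected to Hold

This account rests on a few compounds, and the source may have more. Where it says the series, first, only, none or still open, it means among the compounds named here.

Three close relatives have been measured in a functional assay on DU-145 cells (Homo sapiens) for cytotoxicity; a higher number here means a weaker inhibitor, a lower number a stronger inhibitor. Compound 1 `C=CCC/C=C\C=C/CCCCCCCC[C@@H]1CC[C@@H]([C@@H]2CC[C@@H](CC(=O)OC)OO2)O1` gives 0.1 ug/mL. Compound 2 `C=CCC/C=C\C=C/CCCCCCCC[C@H]1CC[C@@H]([C@@H]2CC[C@@H](CC(=O)O)OO2)O1` gives 0.1 ug/mL, and compound 3 `C=CCC/C=C\C=C/CCCCCCCC[C@@H]1CC[C@@H]([C@@H]2CC[C@@H](CC(=O)O)OO2)O1` gives 0.1 ug/mL. Compound 1 therefore stands level with compounds 2 and 3. The step of no change at the digits printed from compound 1 to compound 3 (within the scatter) puts hydrogen in place of methyl on an oxygen next to a carbonyl group, and the step of no change at the digits printed from compound 2 to compound 3 (within the scatter) turns a stereocentre at a saturated ring carbon from S to R; both stay within the scatter.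

Compound 4 `C=CCC/C=C\C=C/CCCCCCCC[C@H]1CC[C@H]([C@@H]2CC[C@@H](CC(=O)OC)OO2)O1` is not yet measured. Compared with compound 1 it keeps every atom and bond: the two compounds have the same atoms and bonds and differ only in configuration as drawn: 2 of 6 stereo elements differ; a stereocentre at a saturated ring carbon is drawn R in compound 1 and S in compound 4; a stereocentre at a saturated ring carbon is drawn S in compound 1 and R in compound 4. The step from compound 2 to compound 3 bears directly on this, because the fact that compounds 2 and 3 differ only in the configuration as drawn shows that inverting one such ring stereocentre left the value unchanged. For the measured compounds named here, compound 4 inverts two, yet the only evidence says such inversions cost nothing, so the expected step of no change at the digits printed from compound 1 to compound 4 (within the scatter) is none beyond the scatter. Compound 4 is estimated at 0.1 ug/mL, with a range from 0.04 ug/mL to 0.3 ug/mL.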

Compound 4, half-maximal inhibitory concentration: 0.1 ug/mL
Beside the measured number, compound 4's estimate shows no gap at the digits printed, and the stated range covers the measured number.
By their numbers in this assay, from the lowest: compounds 1, 2, 3 and 4 (each within the scatter of the next).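

For the compounds shown here, the earlier pair showed only a single ring stereocentre inverted, and that was in the carboxylic acid series. This result extends the picture to two ring stereocentres inverted together, in the methyl ester series, and this assay records no change at the digits printed from compound 1 to compound 4 (within the scatter). For these compounds, then, the read-out does not separate the two arrangements, whether one centre or two differ, and the pair that shows this for two centres is the following: the fact that compounds 1 and 4 differ only in the configuration as drawn

As far as these compounds go, the other four stereo elements are the same in all four compounds, so the effect of inverting any of them remains unknown. From the compounds shown here alone, it is also open whether the value would hold with an amide in place of the methyl ester, or with a shorter chain in place of the long unsaturated one.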